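Oxygen-linked replacements for the 4-ethylpiperidin-1-yl group

The source may hold more compounds than are shown below. What is called first, only, known or untested is meant among the compounds shown, and "the series" means these compounds.

For the measured compounds named here, compound 1 `CCC1CCN(c2nc(C(C)(C)C)ccc2CNC(=O)C(C)c2ccc(NS(C)(=O)=O)c(F)c2)CC1` carries a 4-ethylpiperidin-1-yl group on the shared core, and in an assay on cells for antagonist activity at transient receptor potential cation channel subfamily V member 1 (Homo sapiens), read by FLIPR and calcium flux, with a stated time of 6 min (on this read-out higher numbers stand for weaker inhibition and lower numbers for stronger inhibition), compound 1 gives 0.1 nM, the lowest of the three numbers measured so far. Compound 2 `CCCCCCOc1nc(C(C)(C)C)ccc1CNC(=O)C(C)c1ccc(NS(C)(=O)=O)c(F)c1` gives 2.7 nM and compound 3 `CC(C(=O)NCc1ccc(C(C)(C)C)nc1OC1CCCC1)c1ccc(NS(C)(=O)=O)c(F)c1` gives 1.5 nM. Both oxygen-linked replacements for the 4-ethylpiperidin-1-yl group move the number upward: a 27-fold higher number from compound 1 to compound 2 (1.43 log units; beyond the scatter) and a 15-fold higher number from compound 1 to compound 3 (1.18 log units; beyond the scatter). Between the two oxygen-linked groups themselves the gap is small: a 1.8-fold lower number from compound 2 to compound 3 (0.26 log units; within the scatter).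

Compound 4 `CC(C(=O)NCc1ccc(C(C)(C)C)nc1OCc1ccc(F)cc1)c1ccc(NS(C)(=O)=O)c(F)c1` is the next step from compound 1: (4-fluorobenzyl)oxy in place of 4-ethylpiperidin-1-yl on an aromatic carbon. The two measured steps away from compound 1 bear on it directly; both were large and in the same direction, so a large upward step is expected here as well. Whether a (4-fluorobenzyl)oxy group lands nearer to hexyloxy or to cyclopentyloxy cannot be told from these three compounds. For compound 4 the expected step is a 25-fold higher number from compound 1 to compound 4 (1.40 log units; beyond the scatter). Compound 4 is estimated at 2.5 nM, with a range from 0.5 nM to 12 nM.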

Compound 4, inhibition constant: 0.8 nM
Estimate against measurement, compound 4: 3.1-fold (0.49 log units) above; measured number inside the range.
By their numbers in this assay, from the lowest: compound 1; then compounds 4, 3 and 2 (each within the scatter of the next, the first and the last beyond it).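

In this assay, the (4-fluorobenzyl)oxy group brings a six-membered aromatic ring of carbon only to this position, and it still falls short of the 4-ethylpiperidin-1-yl group (a modest step: an 8.0-fold higher number from compound 1 to compound 4 (0.90 log units; beyond the scatter)). The group on the oxygen now makes a measurable difference, which the two earlier oxygen-linked compounds did not show: the step from hexyl to 4-fluorobenzyl lies beyond the scatter (a 3.4-fold lower number from compound 2 to compound 4 (0.53 log units; beyond the scatter)). The step from cyclopentyl to 4-fluorobenzyl lies within it (a 1.9-fold lower number from compound 3 to compound 4 (0.27 log units; within the scatter)), so these two groups on the oxygen cannot be told apart here.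

Open, as far as these compounds go, is whether a nitrogen-linked benzylamine or a morpholine at this position would come closer to compound 1, and whether the ring fluorine of the benzyl group matters. Nothing available explains any of these steps.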